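Two Methyl Groups on the Ring of Compound 3

A few compounds are considered here, and "the series" means these few. Any claim that something is new, unique, unknown or untested is made for them only; others in the source may bear on it.

Compound 1 `C[C@@H](/N=C(\S)Nc1ccc(Cl)cn1)c1cccc2ccccc12` and compound 2 `Cc1ccc(N/C(S)=N/[C@H](C)c2cccc3ccccc23)nc1` are close relatives that differ in the group carried on the amine nitrogen. In a functional assay on RBL-2H3 cells (Rattus norvegicus) for inhibition (on this read-out lower numbers stand for stronger inhibition and higher numbers for weaker inhibition), compound 1 gives only a limit, > 100000 nM; > 100000 nM (2 entries), so no number is known for it. Compound 2 in this assay gives 5 nM, the only number shown in this series, with one further entry for it that lacks a single number. Compound 3 `Cc1cc(C)nc(N/C(S)=N/[C@H](C)c2cccc3ccccc23)c1` has not been measured yet; it is made from compound 2 by one change, (4,6-dimethylpyridin-2-yl in place of 5-methylpyridin-2-yl on an amine nitrogen). Going by the values given here, no step between two measured compounds is known here, so there is nothing to show how a change on this ring moves the read-out. The ring itself is kept, one methyl is moved and a second is added, and such a change is expected to cost some potency but not much, so the step from compound 2 to compound 3 is estimated as a 4.0-fold higher number from compound 2 to compound 3 (0.60 log units; beyond the scatter), a modest weakening a little beyond the scatter. Compound 3 is therefore expected to give about 20 nM in this assay, with a plausible range from 4 nM to 150 nM.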

Compound 3, half-maximal inhibitory concentration: > 100000 nM
Compound 3 ended at the assay's limit; the forecaster's own chance of this, stated with the estimate: 5%; middle value at least 5000-fold (3.69 log units) away from the limit.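

In this assay, going by these compounds alone, the first readable change at this place, 4,6-dimethylpyridin-2-yl in place of 5-methylpyridin-2-yl on an amine nitrogen, gives an at least 20000-fold higher number from compound 2 to compound 3 (4.30 log units; beyond the scatter). The ring stays a six-membered aromatic ring with 1 hetero atom, and the counted hydrogen-bond donors and acceptors stay the same, so the strong inhibition seen with compound 2 does not carry over to every methyl-bearing ring of this kind. The reading for compound 3 is a limit of the assay and not a number, so the step gives only the smallest possible size of the change: the limit of > 100000 nM in this assay, at which 1 of the 3 values shown sits.

The compounds shown cannot tell whether the loss follows from removing the methyl of the 5-methylpyridin-2-yl group or from introducing either of the two methyls of the 4,6-dimethylpyridin-2-yl group, and they give no reason for so large a change. They also leave open how the read-out would respond to a methoxy group or an amine on this ring.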